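Swapping Benzodioxin for Trifluoromethylphenyl: Cytotoxicity Expectation

This account rests on a few compounds, and the source may have more. Where it says the series, first, only, none or still open, it means among the compounds named here.

Compounds measured so far:
Compound 1 `CCOC(=O)CCCCCOc1cccc(CN(C(=O)c2ccc(-c3ccc4ccccc4c3)cc2)C(C)C)c1`: in an ADME assay on Raji cells (Homo sapiens) for cytotoxicity, read by CellTiter-Glo and resazurin assay, with a stated time of 72 h (on this read-out lower numbers stand for an effect already at smaller amounts and higher numbers for an effect only at larger amounts of compound), compound 1 gives > 26000 nM, which is a limit of the assay.
Compound 2 `CCOC(=O)CCCCCOc1cccc(CN(C(=O)c2ccc(-c3cccc(OC(C)C)c3)cc2)C(C)C)c1`: compound 2 gives > 26000 nM, again only a limit.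
Compound 3 `CCOC(=O)CCCCCOc1cccc(CN(C(=O)c2ccc(-c3ccc4c(c3)OCCO4)cc2)C(C)C)c1`: compound 3 gives > 24400 nM, also a limit.

Compound 3 therefore stands at a limit, exactly like the two other compounds, as the limit of > 24400 nM in this assay, at which 1 of the 3 values shown sits, and the limit of > 26000 nM in this assay, at which 2 of the 3 values shown sit, record. Compound 4 `CCOC(=O)CCCCCOc1cccc(CN(C(=O)c2ccc(-c3cccc(C(F)(F)F)c3)cc2)C(C)C)c1` carries the change (3-(trifluoromethyl)phenyl in place of 2,3-dihydro-1,4-benzodioxin-6-yl on an aromatic carbon). The steps a step that the two limits leave unreadable from compound 1 to compound 3 and a step that the two limits leave unreadable from compound 2 to compound 3 bear on this change, yet neither can be sized, since every value involved is a limit. No step beyond the usual scatter is expected in this assay; compound 4 is expected to stay at a limit as well, giving a step that the limit leaves unreadable from compound 3 to compound 4. The estimate for compound 4 is 30000 nM, ranging from 15000 nM to 60000 nM.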

Compound 4, half-maximal effective concentration: > 26000 nM
Compound 4 gave a limit, no number; the forecaster's own chance of this, stated with the estimate: 85%; the middle value is on the limit's open side.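

Compound 4 gives only a limit, as do compound 1, compound 2 and compound 3, and no step among these four compounds can be read. The compounds shown leave open where their true values lie and whether exchanging these groups changes the effect on the cells at all.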